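This account rests on a few compounds, and the source may have more. Where it says the series, first, only, none or still open, it means among the compounds named here.

Measured in a functional assay on SK-OV-3 cells (Homo sapiens) for antiproliferative activity; a higher number here means a weaker inhibitor of growth, a lower number a stronger inhibitor of growth:
Compound 1 `c1ccc(-c2cc(-c3ccsc3)cc(-c3cccnc3)n2)nc1`: > 100 ug/mL, a limit of the assay.
Compound 2 `c1ccc(-c2cc(-c3cccs3)cc(-c3ccncc3)n2)nc1`: 48.3 ug/mL.

Among the measured compounds shown here, compound 2 holds the only actual number so far. Compound 3 `c1ccc(-c2cc(-c3cccs3)cc(-c3cccnc3)n2)nc1` is compound 2 with pyridin-3-yl in place of pyridin-4-yl on an aromatic carbon. Compound 1, which also carries pyridin-3-yl, stands at > 100 ug/mL, and that value is a limit. A modest weakening is therefore expected in this assay, perhaps no larger than the usual scatter. The expected change is a 1.3-fold higher number from compound 2 to compound 3 (0.13 log units; within the scatter). For compound 3 the estimate is 65 ug/mL, with an expected range of 30 ug/mL to 100 ug/mL.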

Compound 3, concentration for 50% growth inhibition: 52 ug/mL
The estimate for compound 3 lay 1.3-fold (0.10 log units) above the measured number; the range from low to high includes it.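

In this assay, pyridin-3-yl in place of pyridin-4-yl gives a 1.1-fold higher number from compound 2 to compound 3 (0.03 log units; within the scatter) and so does not separate the two compounds when thiophen-2-yl is present. Thiophen-2-yl in place of thiophen-3-yl gives an at least 1.9-fold lower number from compound 1 to compound 3 (0.28 log units; that floor lies within the scatter) and is the first reading on the thiophene attachment with pyridin-3-yl held fixed. On these data alone, the true size of that step stays unknown because compound 1 sits at a limit: the limit of > 100 ug/mL in this assay, at which 1 of the 3 values shown sits.

Still open, as far as these compounds go, is whether the pyridine exchange reads the same with thiophen-3-yl present. Also open, from the compounds shown here alone, is how an amine or a carboxylic acid would compare in place of the pyridinyl group.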